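This account rests on a few compounds, and the source may have more. Where it says the series, first, only, none or still open, it means among the compounds named here.

Measured compounds:
- Compound 1 `NC(=O)c1c(NC(=O)c2ccccc2Cl)sc2c1CCN(C(=S)Nc1cc(C(F)(F)F)cc(C(F)(F)F)c1)C2`: in a functional assay on MKN-74 cells (Homo sapiens) for antiproliferative activity, with a stated time of 24 h (a higher number here means a weaker inhibitor, a lower number a stronger inhibitor), compound 1 gives 15000 nM
- Compound 2 `NC(=O)c1c(NC(=O)c2ccc(C(F)(F)F)cc2)sc2c1CCN(C(=S)Nc1cc(C(F)(F)F)cc(C(F)(F)F)c1)C2`: in this assay compound 2 gives 13800 nM
- Compound 3 `Cc1ccc(C(=O)Nc2sc3c(c2C(N)=O)CCN(C(=S)Nc2cc(C(F)(F)F)cc(C(F)(F)F)c2)C3)cc1`: in this assay compound 3 gives 14900 nM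

All three share one core and differ only in the aryl group attached to the carbonyl carbon of the amide. Compound 3 sits among values that are all within the scatter of one another: a 1.0-fold lower number from compound 1 to compound 3 (0.00 log units; within the scatter) and a 1.1-fold higher number from compound 2 to compound 3 (0.03 log units; within the scatter), so no ordering among the three can be claimed.

Compound 4 `NC(=O)c1c(NC(=O)c2cccc([N+](=O)[O-])c2)sc2c1CCN(C(=S)Nc1cc(C(F)(F)F)cc(C(F)(F)F)c1)C2` has not yet been measured in this assay. It differs from compound 3 as follows: 3-nitrophenyl in place of 4-methylphenyl on a carbonyl carbon. The measured steps that bear on this change are all swaps of the aryl group at the same carbonyl carbon: a 1.1-fold lower number from compound 1 to compound 2 (0.04 log units; within the scatter), a 1.0-fold lower number from compound 1 to compound 3 (0.00 log units; within the scatter) and a 1.1-fold higher number from compound 2 to compound 3 (0.03 log units; within the scatter). Each of them stays within the scatter, whether the aryl group carries a chloro, a trifluoromethyl or a methyl substituent. On that basis the expected step in this assay from compound 3 to compound 4 is none beyond the scatter, a 1.0-fold higher number from compound 3 to compound 4 (0.00 log units; within the scatter). Compound 4 is therefore estimated at 15000 nM, with a likely range from 7000 nM to 32000 nM.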

Compound 4, half-maximal inhibitory concentration: 25800 nM
Estimate against measurement, compound 4: 1.7-fold (0.24 log units) below; low and high end bracket the measured number.
By their numbers in this assay, from the lowest: compounds 2, 3, 1 and 4 (each within the scatter of the next).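

Placing 3-nitrophenyl on the carbonyl carbon gives, in this assay, a 1.7-fold higher number from compound 3 to compound 4 (0.24 log units; within the scatter), a 1.9-fold higher number from compound 2 to compound 4 (0.27 log units; within the scatter) and a 1.7-fold higher number from compound 1 to compound 4 (0.24 log units; within the scatter). These steps are larger than any among the first three compounds, yet each remains within the scatter, so the flat picture at this position now extends beyond chloro, trifluoromethyl and methyl substituents to a nitro group, which brings nitrogen and oxygen atoms and two hydrogen-bond acceptors onto the aryl ring, and no ordering of the four compounds can be claimed. No measurement is available that could explain the size of these steps.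

Going by these compounds, all four compounds keep a substituted phenyl ring on this carbonyl carbon and share the rest of their structure, so it remains open whether any change here can move the number beyond the scatter. On these data alone, an amine or a carboxylic acid on the phenyl ring, or a longer alkyl chain in place of the ring, would test this, and the effect of changes elsewhere on the shared core also remains open.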